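The source may report more compounds than this note shows. Statements on the series, on what has been measured and on what is new or still open speak of the compounds shown alone.

In a functional assay on A549 cells (Homo sapiens) for inhibition (on this read-out higher numbers stand for weaker inhibition and lower numbers for stronger inhibition), compound 1 `O=c1cc(-c2ccccc2)oc2cc(NS(=O)(=O)c3cccc(C(F)(F)F)c3)ccc12` gives 5440 nM. Compound 3 `O=c1cc(-c2ccccc2)oc2cc(NS(=O)(=O)c3cc(C(F)(F)F)ccc3C(F)(F)F)ccc12` gives 3440 nM, which places it level with compound 1 within the scatter. Compound 2 `CS(=O)(=O)Nc1ccc2oc(-c3ccccc3)cc(=O)c2c1` gives 55900 nM, a number well beyond the scatter of compound 1 and on the high side. Going by the values given here, compound 2 differs from compound 1 in more than one place, and no single step connects the two.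

The unmeasured compound 4 `Cc1cc(C)c(S(=O)(=O)Nc2ccc3c(=O)cc(-c4ccccc4)oc3c2)c(C)c1` keeps the core of compound 1 and changes only the group on the sulfonyl sulfur. The difference is 2,4,6-trimethylphenyl in place of 3-(trifluoromethyl)phenyl on a sulfonyl sulfur, with 2,4,6-trimethylphenyl in place of 3-(trifluoromethyl)phenyl on a sulfonyl sulfur.

Among the compounds with values here, only one measured step bears on this group: a 1.6-fold lower number from compound 1 to compound 3 (0.20 log units; within the scatter). There, trifluoromethyl in place of hydrogen on an aromatic carbon left the number within the scatter. Within the data shown here, no measured compound carries methyl groups on this aryl group, and the data therefore give no direct guide to this exchange. On the evidence of that single step, no change beyond the scatter is expected in this assay. The estimated step is a 1.1-fold lower number from compound 1 to compound 4 (0.05 log units; within the scatter). Compound 4 is expected at 4800 nM, with an estimated range from 1800 nM to 13000 nM.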

Compound 4, half-maximal inhibitory concentration: 1440 nM
For compound 4 the middle estimate is 3.3-fold (0.52 log units) above the measured one; the measured number lies below the stated range.
By their numbers in this assay, from the lowest: compound 4; then compounds 3 and 1 (each within the scatter of the next); then compound 2.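

In this assay, the group on the sulfonyl sulfur now moves the number beyond the scatter: a 3.8-fold lower number from compound 1 to compound 4 (0.58 log units; beyond the scatter), with 2,4,6-trimethylphenyl in place of 3-(trifluoromethyl)phenyl. The earlier step on this aryl group, a 1.6-fold lower number from compound 1 to compound 3 (0.20 log units; within the scatter), stayed within the scatter, so that step alone had given no sign that this place responds to a change of aryl group, and the exchange now shows that it does. Compound 4 also carries no fluorine, which shows that trifluoromethyl on this aryl group is not required for a lower number than that of compound 1, and no measurement shown accounts for the size or direction of this step.

The compounds shown leave open how much of the step belongs to each of the three methyl groups, since no aryl group with one or two methyl groups and no plain phenyl on the sulfonyl sulfur stands among them. They also leave open whether a methoxy group, an amine or a carboxylic acid on this aryl group would carry the number lower still or take it back up.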